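The compounds below may be only part of what the source reports. "The series", "measured", "known", "first", "only" and "open" are said of these compounds alone.

Of the compounds shown here, three built on a shared core have been measured in a functional assay on MDA-MB-435 cells (Homo sapiens) for cytotoxicity, read by sulforhodamine B assay, with a stated time of 48 h, tested at 10 uM; on this read-out higher numbers stand for a weaker effect at the one concentration tested and lower numbers for a stronger effect. Compound 2 `COc1cc(-c2cc(/C=C/C(=O)c3ccc(N)cc3)[nH]n2)cc(OC)c1OC` stands lowest of the three, giving -86%. Compound 3 `COc1ccc(C(=O)/C=C/c2cc(-c3cc(OC)c(OC)c(OC)c3)n[nH]2)cc1`, which differs from it by a methoxy in place of amino on an aromatic carbon, gives -30%, so that the step of a number 56 percentage points higher from compound 2 to compound 3 (beyond the scatter). Compound 1 `COc1ccc(-c2cc(/C=C/C(=O)c3ccc(N)cc3)[nH]n2)cc1` differs from compound 2 at several places; in this assay compound 1 gives -16% and lies furthest from compound 2.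

The step now followed leads from compound 2 to compound 4 `COc1ccc(-c2cc(/C=C/C(=O)c3ccc(N)cc3)[nH]n2)cc1OC`, with the change (hydrogen in place of methoxy on an aromatic carbon). Among the measured compounds shown here, no measured step covers this change directly. For the measured compounds named here, the one measured step, from compound 2 to compound 3, alters a different place and shows only how far a single change can move the number here. Going by the values given here, the pair compound 1 and compound 2 is joined by no single step, but their two values show that the compound with fewer methoxy groups gives the much higher number. Compound 4 is intermediate between them in that respect, so a step upward from compound 2, short of the gap to compound 1, is expected. Compound 4 is therefore estimated to give -45%, within -80% to -10%, an expected step of a number 41 percentage points higher from compound 2 to compound 4 (beyond the scatter).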

Compound 4, a percentage reported as activity, at one concentration (the size of the read-out at that concentration, not a potency): -15%
The estimate for compound 4 lay 30 percentage points below the measured number; the range from low to high includes it.
By their numbers in this assay, from the lowest: compound 2; then compound 3; then compounds 1 and 4 (each within the scatter of the next).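

In this assay, among the compounds shown here, the single methoxy group on this aromatic carbon, ortho to a methoxy group and meta to a large group, turns out to carry almost all of the difference seen earlier between the compounds with more and fewer methoxy groups: hydrogen in its place gives a number 71 percentage points higher from compound 2 to compound 4 (beyond the scatter). The other single methoxy change does not share in this, for methoxy in place of hydrogen gives a number 1 percentage points higher from compound 1 to compound 4 (within the scatter), so among these compounds the number does not follow a simple count of methoxy groups, and only compound 2, with all three, stands apart from compound 1 and compound 4. Nothing available here offers an explanation for why this one change matters so much.

On these data alone, whether a hydroxy group, an ethoxy group or a fluorine atom on this carbon would keep the number near that of compound 2 or leave it near that of compound 4 remains open. Also open, as far as these compounds go, is whether methoxy in place of amino, the change separating compound 2 from compound 3, would move the number at all on the core of compound 4.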